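Bromo step carried from the first core to the second

A few compounds are considered here, and "the series" means these few. Any claim that something is new, unique, unknown or untested is made for them only; others in the source may bear on it.

Measured compounds in a functional assay on cells (Cancer cell lines, Homo sapiens) for cytotoxicity, read by sulforhodamine B assay, with a stated time of 48 h; on this read-out lower numbers stand for stronger inhibition of growth and higher numbers for weaker inhibition of growth:
compound 1 `O=C1N=C(N2N=C(c3ccccc3)CC2c2ccccc2O)S/C1=C1/C(=O)Nc2ccccc21`; compound 1 gives 2090 nM
compound 2 `O=C1N=C(N2N=C(c3ccccc3)CC2c2ccccc2O)S/C1=C1/C(=O)Nc2ccc(Br)cc21`; compound 2 gives 260 nM
compound 3 `COc1ccc(C2=NN(C3=NC(=O)/C(=C4\C(=O)Nc5ccccc54)S3)C(c3ccc(Cl)cc3)C2)cc1`; compound 3 gives 100000 nM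

The change bromo in place of hydrogen on an aromatic carbon produced an 8.0-fold lower number from compound 1 to compound 2 (0.91 log units; beyond the scatter). Compound 3 stands on a different core; the difference between the two cores is not broken down here, and compound 3 gives the highest number of the three.

Among the compounds with values here, compound 4 `COc1ccc(C2=NN(C3=NC(=O)/C(=C4\C(=O)Nc5ccc(Br)cc54)S3)C(c3ccc(Cl)cc3)C2)cc1` differs from compound 3 by bromo in place of hydrogen on an aromatic carbon, the same kind of change as the one from compound 1 to compound 2, with the place described in the same words. Within the data shown here, only one earlier instance of the change is available, so the transfer rests on a single step.

For compound 4 the expected step is a 6.7-fold lower number from compound 3 to compound 4 (0.82 log units; beyond the scatter), because the earlier instance gave an 8.0-fold lower number from compound 1 to compound 2 (0.91 log units; beyond the scatter). Compound 4 is therefore estimated at 15000 nM, with a range from 3000 nM to 100000 nM.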

Compound 4, concentration for 50% growth inhibition: 140 nM
For compound 4 the middle estimate is 110-fold (2.03 log units) above the measured one; the measured number lies below the stated range.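

In this assay the bromo change gives a 710-fold lower number from compound 3 to compound 4 (2.85 log units; beyond the scatter), so the direction of the earlier step holds on the second core. The size of the step does not carry over: the same change on two cores in this assay, an 8.0-fold lower number (0.91 log units; beyond the scatter) from compound 1 to compound 2 and a 710-fold lower number (2.85 log units; beyond the scatter) from compound 3 to compound 4, 89-fold (1.95 log units) apart, beyond the scatter of two such steps The two cores differ in more than one place, so these data do not show which difference goes with the larger step, and two cores give no rule for predicting its size on a third.

Still open, going by these compounds, is whether fluoro, an amine or a carboxylic acid on the same aromatic carbon would follow bromo on either core. Also open, on these data alone, is how large the bromo step would be on a core carrying only one of the differences between these two.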